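Cyclohexyl for sec-butyl on a curcumin-like amine

The source may report more compounds than this note shows. Statements on the series, on what has been measured and on what is new or still open speak of the compounds shown alone.

Measured compounds:
- compound 1, `CCC(C)NC(=C\C(=O)/C=C/c1ccc(O)c(OC)c1)/C=C/c1ccc(O)c(OC)c1`: 85%
- compound 2, `COc1cc(/C=C/C(=O)/C=C(/C=C/c2ccc(O)c(OC)c2)NC2CCCCC2)ccc1O`: 91%
- compound 3, `CCC(C)NC(=C\C(=O)/C=C/c1ccc(O)cc1)/C=C/c1ccc(O)cc1`: 99%

All three were tested in a functional assay on EA.hy 926 cells (Homo sapiens), read by fluorescence, tested at 1 uM; on this read-out higher numbers stand for a stronger effect at the one concentration tested and lower numbers for a weaker effect. Compound 1 and compound 2 share one core, and compound 3 carries a second core; the difference between the two cores is not broken down here. Within the first core, the only change is cyclohexyl in place of sec-butyl on an amine nitrogen, and the step it made was a number 6 percentage points higher from compound 1 to compound 2 (within the scatter). Compound 3 stands nearest to compound 2: compound 2 gives 91% and compound 3 gives 99%, a gap that is within the scatter; compound 1 gives 85%, and its gap to compound 3 is beyond the scatter.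

Compound 4, `O=C(/C=C(/C=C/c1ccc(O)cc1)NC1CCCCC1)/C=C/c1ccc(O)cc1`, has not yet been measured. It relates to compound 3 in the same way that compound 2 relates to compound 1: the change is cyclohexyl in place of sec-butyl on an amine nitrogen, and the place of the change is the same, an amine nitrogen whose other neighbour is a double-bonded chain carbon, so it is the same change, not merely the same kind.

Because the earlier step of a number 6 percentage points higher from compound 1 to compound 2 (within the scatter) stayed within the scatter, the expected step here is also small, no change at the digits printed from compound 3 to compound 4 (within the scatter), and because compound 3 already gives 99% there is little room for the number to rise. The estimate for compound 4 in this assay is therefore 99%, expected to fall between 90% and 105%.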

Compound 4, a percentage reported as activity, at one concentration (the size of the read-out at that concentration, not a potency): 129%
The estimate for compound 4 lay 30 percentage points below the measured number, outside the stated range (above it).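

In this assay, putting cyclohexyl in place of sec-butyl on the amine nitrogen of the second core gave a clear rise (a number 30 percentage points higher from compound 3 to compound 4 (beyond the scatter)). So in this series the change did not carry over from one core to the other with the same size, and a step measured on one core was a poor guide to the step on the other: the same change on two cores in this assay, a number 6 percentage points higher (within the scatter) from compound 1 to compound 2 and a number 30 percentage points higher (beyond the scatter) from compound 3 to compound 4, 24 percentage points apart, beyond the scatter of two such steps. This does not show what in the cores makes the two steps differ, whether the gap would appear on a third core, or how these compounds would rank across a range of concentrations, since each number describes a single tested concentration and is not a potency.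

The compounds shown carry only sec-butyl and cyclohexyl on that nitrogen, so it remains open whether a cyclopentyl ring, a phenyl ring or a straight butyl chain there would also give a step that depends on the core. With just two cores and one pair on each, the series also leaves open whether the larger step on the core of compound 3 is specific to cyclohexyl.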